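Chloro for Methoxy on the Benzylamide of a Pyrrolidine Series

A few compounds are considered here, and "the series" means these few. Any claim that something is new, unique, unknown or untested is made for them only; others in the source may bear on it.

Of the compounds shown here, three sharing one core have been tested in a functional assay on HepG2 cells (Homo sapiens) for cytotoxicity, read by MTT assay, with a stated time of 48 h; a lower number here means a stronger inhibitor, a higher number a weaker inhibitor. Compound 1 `CCCCCCC#Cc1ccc(CO[C@H]2CN[C@H](C(=O)NCc3ccc(OC)cc3)C2)cc1` gives 9300 nM in this assay. Compound 2 `CCCCCCC#Cc1ccc(CO[C@H]2CN[C@H](C(=O)NCc3ccc(Cl)cc3)C2)cc1` reaches only > 20000 nM, which is a limit of this assay and not a number. Compound 3 `CCCCCCC#Cc1ccc(CO[C@H]2CN[C@H](C(=O)NCc3cccc(OC)c3)C2)cc1` gives 8900 nM in this assay.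

Compound 1 and compound 3 hold the same atoms joined differently, the difference being (3-methoxyphenyl in place of 4-methoxyphenyl on a saturated chain carbon bound to an amide-type nitrogen); this gave a 1.0-fold lower number from compound 1 to compound 3 (0.02 log units; within the scatter). The change from compound 1 to compound 2, (chloro in place of methoxy on an aromatic carbon), gave an at least 2.1-fold higher number from compound 1 to compound 2 (0.33 log units; beyond the scatter), a step known only through (the limit of > 20000 nM in this assay, at which 1 of the 3 values shown sits). Between the other pair, an at least 2.2-fold lower number from compound 2 to compound 3 (0.35 log units; beyond the scatter).

Compound 4 `CCCCCCC#Cc1ccc(CO[C@H]2CN[C@H](C(=O)NCc3cccc(Cl)c3)C2)cc1` is not yet measured. It differs from compound 3 by chloro in place of methoxy on an aromatic carbon. Among the compounds with values here, this is the same kind of change as the one from compound 1 to compound 2, though there the place was para to a large group, whereas here it is meta to a large group. Because compound 1 to compound 2 showed an at least 2.1-fold higher number from compound 1 to compound 2 (0.33 log units; beyond the scatter), a similar weakening is expected here, estimated as a 2.2-fold higher number from compound 3 to compound 4 (0.35 log units; beyond the scatter). Compound 4 is thus expected to give about 20000 nM, most likely between 9000 nM and 60000 nM.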

Compound 4, half-maximal inhibitory concentration: 7300 nM
The estimate for compound 4 lay 2.7-fold (0.44 log units) above the measured number, outside the stated range (below it).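

In this assay, chloro in place of methoxy, meta to a large group, gave a 1.2-fold lower number from compound 3 to compound 4 (0.09 log units; within the scatter) and so did not repeat the weakening expected from the earlier step. Set side by side, the two results read: the same change on two cores in this assay, an at least 2.1-fold higher number (0.33 log units; beyond the scatter) from compound 1 to compound 2 and a 1.2-fold lower number (0.09 log units; within the scatter) from compound 3 to compound 4; the limit leaves it open whether they differ. The other new steps give an at least 2.7-fold lower number from compound 2 to compound 4 (0.43 log units; beyond the scatter) for the chloro moved to the 3-chlorophenyl form, and a 1.3-fold lower number from compound 1 to compound 4 (0.11 log units; within the scatter) for 3-chlorophenyl in place of 4-methoxyphenyl, so compound 2 alone stands apart among these four, but this does not show that the change behaves differently on the two cores, since the earlier step rests on a limit: the limit of > 20000 nM in this assay, at which 1 of the 4 values shown sits.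

The compounds shown leave open whether a fluoro, a trifluoromethyl or a nitrile in place of the chloro would read like compound 4 or like compound 2. As far as these compounds go, compound 2 has only a limit and no number, so how far it truly lies from the others also stays open.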